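The compounds below may be only part of what the source reports. "The series", "measured", "known", "first", "only" and "open" are said of these compounds alone.

Measured in a functional assay on UACC-62 cells (Homo sapiens) for antiproliferative activity, read by sulforhodamine B assay, with a stated time of 48 h; a lower number here means a stronger inhibitor of growth, a higher number a weaker inhibitor of growth:
- compound 1 `O=C(NCCCNc1cc(-c2cn(-c3ccccc3)nc2-c2cccc(O)c2)ccn1)Nc1ccc(F)cc1`: 6600 nM
- compound 2 `O=C(NCCCNc1cc(-c2cn(-c3ccccc3)nc2-c2cccc(O)c2)ccn1)Nc1cccc(C(F)(F)F)c1`: 8840 nM

Within the data shown here, compound 1 has only one measured neighbour on this scale, compound 2, and the two values lie within the scatter of each other. They cannot be ranked.

Compound 3 `COc1cccc(-c2nn(-c3ccccc3)cc2-c2ccnc(NCCCNC(=O)Nc3ccc(F)cc3)c2)c1` is compound 1 with one change: methyl in place of hydrogen on an oxygen on an aromatic ring. This is hydroxy to methoxy, or 3-hydroxyphenyl to 3-methoxyphenyl, with the rest of the molecule untouched.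

Among the measured compounds shown here, the only measured step is a 1.3-fold higher number from compound 1 to compound 2 (0.13 log units; within the scatter). It replaces the group on an amide-type nitrogen, not the group on the oxygen, so it bears on the new change only indirectly. It shows that one change elsewhere in the molecule left this assay within the scatter. For the measured compounds named here, no measured pair tests the hydroxy group itself, so the data give no direction for this step and the range has to stay wide.

No shift beyond the scatter is expected, and the expected step is a 1.1-fold higher number from compound 1 to compound 3 (0.03 log units; within the scatter). For compound 3 the estimated value is 7000 nM, with an expected range of 2500 nM to 20000 nM.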

Compound 3, concentration for total growth inhibition: 24200 nM
Estimate against measurement, compound 3: 3.5-fold (0.54 log units) below, outside the stated range (above it).
By their numbers in this assay, from the lowest: compounds 1 and 2 (each within the scatter of the next); then compound 3.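

In this assay, the step from hydroxy to methoxy gives a 3.7-fold higher number from compound 1 to compound 3 (0.56 log units; beyond the scatter) and so weakens growth inhibition modestly. Among these compounds, the change on the amide-type nitrogen, by contrast, gives a 1.3-fold higher number from compound 1 to compound 2 (0.13 log units; within the scatter), so the oxygen on the 3-hydroxyphenyl group is the first place in this short series where one change moves the number beyond the scatter, and there the hydrogen on the oxygen cannot be replaced by methyl without a loss. The data at hand offer nothing that bears on what lies behind this shift.

Going by these compounds, two compounds at this position cannot separate the effect of removing the hydroxy hydrogen from that of adding carbon on the oxygen, so it remains open whether an amino group or a bare hydrogen in place of the hydroxy group would follow compound 1 or compound 3, and whether an ethoxy group would go further in the same direction as methoxy. On these data alone, it also remains open whether the same change costs as much when the 3-(trifluoromethyl)phenyl group of compound 2 stands on the amide-type nitrogen.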